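A Sulfonamide Replaces the Sulfonate Ester on a Hindered Phenol

The source may hold more compounds than are shown below. What is called first, only, known or untested is meant among the compounds shown, and "the series" means these compounds.

Compound 3 `COS(=O)(=O)c1cc(C(C)C)c(O)c(C(C)C)c1` stands lowest of the three measured compounds in a physicochemical assay for lipophilicity (a lower number here means a more polar compound, a higher number a more lipophilic compound), where compound 3 gives 3.7; compound 1 `CC(C)c1cc(Cl)cc(C(C)C)c1O` gives 5.34 and compound 2 `CC(C)c1cc(Br)cc(C(C)C)c1O` gives 5.49. The steps down from the halogenated compounds were large: a number 1.64 log units lower from compound 1 to compound 3 (beyond the scatter) and a number 1.79 log units lower from compound 2 to compound 3 (beyond the scatter), whereas a number 0.15 log units higher from compound 1 to compound 2 (within the scatter). Compound 4 `CC(C)c1cc(NS(C)(=O)=O)cc(C(C)C)c1O` carries the change (methanesulfonamido in place of methoxysulfonyl on an aromatic carbon). Among the compounds with values here, no measured step involves methanesulfonamido, so nothing recorded bears directly on this exchange; the two large steps only show how far methoxysulfonyl already sits from the halogens. The exchange is expected to give a modest further decrease, a number 0.40 log units lower from compound 3 to compound 4 (beyond the scatter). Compound 4 is therefore estimated at 3.3, within 2.7 to 3.9.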

Compound 4, partition coefficient: 3.14
Compound 4: the middle estimate sits 0.16 log units above what was measured, within the range that was stated.
By their numbers in this assay, from the lowest: compound 4; then compound 3; then compounds 1 and 2 (each within the scatter of the next).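

In this assay, methanesulfonamido at this position gives the lowest number of the four compounds, and the change from methoxysulfonyl is a modest one (a number 0.56 log units lower from compound 3 to compound 4 (beyond the scatter)) beside the large steps from the halogens (a number 2.35 log units lower from compound 2 to compound 4 (beyond the scatter); a number 2.20 log units lower from compound 1 to compound 4 (beyond the scatter)). The number thus moved beyond the scatter even though the entering and leaving groups hold the same count of heavy atoms and differ in one hydrogen-bond donor. Nothing available explains this step. As far as these compounds go, whether an amine or a carboxylic acid at this position would give a still lower number remains open. So does how a longer chain in place of the methyl of methanesulfonamido would shift it.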